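Replacing a Nitro Group: Cytotoxicity on Rat Cells

A few compounds are considered here, and "the series" means these few. Any claim that something is new, unique, unknown or untested is made for them only; others in the source may bear on it.

Measured compounds:
compound 1 `N=C(N)c1ccc(OCc2ccc([N+](=O)[O-])cc2)c(I)c1`: 10700000 nM
compound 2 `N=C(N)c1ccc(COc2cccc([N+](=O)[O-])c2)cc1`: 57800000 nM
compound 3 `N=C(N)c1ccc(COc2ccc(C(=N)N)cc2I)cc1`: 5300000 nM

All three were tested in an ADME assay on L6 cells (Rattus norvegicus) for cytotoxicity, read by resazurin assay, with a stated time of 72 h; on this read-out lower numbers stand for stronger inhibition and higher numbers for weaker inhibition. Compound 2 stands highest, set apart from both others beyond the scatter, while compound 3 gives the lowest number. Compound 1 and compound 3 differ in a single place: a group of 3 heavy atoms (1 carbon, 2 nitrogen; no ring) in place of a group of 3 heavy atoms (1 nitrogen, 2 oxygen; no ring), on an aromatic carbon. This change produced a 2.0-fold lower number from compound 1 to compound 3 (0.31 log units; beyond the scatter). Compound 2 and compound 1 are not related by a single-point change; the difference between the two cores is not broken down here.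

Compound 4 `N=C(N)c1ccc(COc2cccc(C(=N)N)c2)cc1` has not yet been measured in this assay. It arises from compound 2 by the same kind of change as that from compound 1 to compound 3: a group of 3 heavy atoms (1 carbon, 2 nitrogen; no ring) in place of a group of 3 heavy atoms (1 nitrogen, 2 oxygen; no ring), on an aromatic carbon. The surroundings differ, however: in compound 3 the entering group sits para to a large group, whereas in compound 4 it sits meta to a large group, so this is the same kind of change rather than the same one.

For compound 4 the expected step is a 2.0-fold lower number from compound 2 to compound 4 (0.30 log units; within the scatter). Among the measured compounds shown here, this expectation rests on the single earlier instance, a 2.0-fold lower number from compound 1 to compound 3 (0.31 log units; beyond the scatter), and on nothing more, since no other pair shows this change. For the measured compounds named here, compound 4 is therefore expected to give about 29000000 nM in this assay, with a plausible range from 10000000 nM to 80000000 nM, the range being wide since only one example of the step exists.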

Compound 4, half-maximal inhibitory concentration: 19300000 nM
The estimate for compound 4 lay 1.5-fold (0.18 log units) above the measured number; measured number inside the range.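

In this assay, replacing the nitro group on the core of compound 2 gave a 3.0-fold lower number from compound 2 to compound 4 (0.48 log units; beyond the scatter). The step runs in the same direction as on the core of compound 1, and the two steps do not differ in size by more than the scatter allows: the same change on two cores in this assay, a 2.0-fold lower number (0.31 log units; beyond the scatter) from compound 1 to compound 3 and a 3.0-fold lower number (0.48 log units; beyond the scatter) from compound 2 to compound 4, 1.5-fold (0.17 log units) apart, within the scatter of two such steps. Among the compounds shown here, this shows that the change carried over between these two cores in this one assay, but with only two pairs, and with the entering group in different surroundings on each core, it does not show that the step would hold on any other core, nor do the numbers say why it occurs.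

The compounds shown leave open whether another group in the same place, such as an amine, a carboxylic acid or a nitrile, would move the number as the group entering here does. They also leave open whether the step would persist on a core with a longer chain joining the two aromatic rings.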